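Oral Exposure in Rat: From Compound 2 to Compound 3

The source may report more compounds than this note shows. Statements on the series, on what has been measured and on what is new or still open speak of the compounds shown alone.

Measured compounds:
Compound 1 `Nc1nc(Cl)c(-c2nc3ccccc3s2)c(N[C@@H]2C[C@H](CO)[C@@H](O)[C@H]2O)n1` — 32.6 ng.h/mL
Compound 2 `Cc1nc(NC(C)C)nc(N[C@@H]2C[C@H](CO)[C@@H](O)[C@H]2O)c1-c1nc2ccccc2s1` — 8420 ng.h/mL

Of the compounds shown here, two have been measured in an ADME assay on the whole organism (plasma) for pharmacokinetics, with Rattus norvegicus as the target, with a stated time of 6 h, at a dose of 10 mg/kg by the oral route; on this read-out lower numbers stand for lower exposure and higher numbers for higher exposure at the dose given. Compound 1 gives 32.6 ng.h/mL in this assay. Compound 2 gives 8420 ng.h/mL in this assay, the highest of the two numbers; its nearest neighbour is compound 1, whose number is lower by a gap that lies beyond the scatter. The two compounds differ in more than one place, so no single change can be read from that gap.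

Compound 3 `Cc1nc(NCCOC(C)C)nc(N[C@@H]2C[C@H](CO)[C@@H](O)[C@H]2O)c1-c1nc2ccccc2s1` is not yet measured in this assay. It differs from compound 2 in one place: 2-isopropoxyethyl in place of isopropyl on a nitrogen on an aromatic ring. Within the data shown here, there is no measured pair that isolates this kind of change, so the expectation rests on compound 2 alone as the starting point. Compound 3 is expected to stay in the same broad region as compound 2, with a step of a 2.1-fold lower number from compound 2 to compound 3 (0.32 log units; beyond the scatter) expected to be small, a modest decrease that may not exceed the scatter. The estimate for compound 3 in this assay is 4000 ng.h/mL, with a range from 1000 ng.h/mL to 15000 ng.h/mL.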

Compound 3, area under the concentration-time curve: 426 ng.h/mL
Beside the measured number, compound 3's estimate is 9.4-fold (0.97 log units) above it; measured number outside the range, below it.
By their numbers in this assay, from the lowest: compound 1; then compound 3; then compound 2.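

In this assay, among these compounds, this is the first comparison in which only one place changes, and it shows that exposure responds strongly to the group on this nitrogen: with 2-isopropoxyethyl in place of isopropyl, the result is a 20-fold lower number from compound 2 to compound 3 (1.30 log units; beyond the scatter), a large step well beyond the scatter. The change, which can also be read as isopropylamino to (2-isopropoxyethyl)amino, takes the substituent from 3 to 6 heavy atoms and adds 1 hydrogen-bond acceptor, so a modest-looking extension on this aromatic-ring nitrogen is enough to move the read-out substantially. No measurement at hand explains why the number falls.

The compounds shown change chain size and add the ether oxygen in a single step, leaving open which of these, if either, goes with the lower number; a plain pentyl chain or a shorter 2-methoxyethyl group at this nitrogen would help separate the two. Also open, as far as these compounds go, is whether a terminal amine or carboxylic acid on the chain would fall nearer compound 2 or compound 3, and a single exposure read-out cannot say which underlying processes changed.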